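Iodo-to-methoxy swap on the pendant aryl, compound 3 to compound 4

This account rests on a few compounds, and the source may have more. Where it says the series, first, only, none or still open, it means among the compounds named here.

For the measured compounds named here, compound 3 `Nc1scc(-c2ccc(I)cc2)c1C(=O)c1ccc(Cl)cc1` gives 61% in a functional assay on CHO cells for agonist activity at adenosine receptor A1 (Homo sapiens), read by fluorescence and ERK phosphorylation, with stated times of 30 min and 1.5 h, tested at 10 uM (on this read-out lower numbers stand for a weaker effect and higher numbers for a stronger effect at the one concentration tested), the largest of the three numbers measured so far, though compound 1 `COc1ccc(-c2csc(N)c2C(=O)c2ccccc2)cc1` at 52% lies within the scatter of it. Going by the values given here, compound 2 `Nc1scc(-c2ccc(Br)cc2)c1C(=O)c1ccc(Cl)cc1` gives 46%, and the one single-point step measured, a number 15 percentage points higher from compound 2 to compound 3 (beyond the scatter), is modest. Compound 4 `COc1ccc(-c2csc(N)c2C(=O)c2ccc(Cl)cc2)cc1` differs from compound 3 by methoxy in place of iodo on an aromatic carbon. Among the compounds with values here, no measured step covers this change directly; compound 1 carries the same methoxy on the same ring with an unsubstituted benzoyl and sits close to compound 3. Compound 4 is therefore expected near compound 1 and compound 3, with a number 9 percentage points lower from compound 3 to compound 4 (within the scatter) not clearly beyond the scatter. The estimate for compound 4 is 52%, within 32% to 70%.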

Compound 4, a percentage reported as activity, at one concentration (the size of the read-out at that concentration, not a potency): 55%
For compound 4 the middle estimate is 3 percentage points below the measured one; the measured number falls inside the stated range.
By their numbers in this assay, from the lowest: compounds 2, 1, 4 and 3 (each within the scatter of the next, the first and the last beyond it).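

At this aromatic carbon, para to a large group, methoxy in place of iodo gives a number 6 percentage points lower from compound 3 to compound 4 (within the scatter) in this assay, and methoxy in place of bromo gives a number 9 percentage points higher from compound 2 to compound 4 (within the scatter); methoxy thus cannot be told apart from either halogen, although iodo and bromo differ by a number 15 percentage points higher from compound 2 to compound 3 (beyond the scatter). With methoxy held in place, chloro in place of hydrogen on an aromatic carbon gives a number 3 percentage points higher from compound 1 to compound 4 (within the scatter). No measurement here explains these steps. On these data alone, whether an amine or a carboxylic acid at this position would give a step beyond the scatter stays open. As far as these compounds go, how these single-concentration numbers would rank as potencies also stays open.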